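This account rests on a few compounds, and the source may have more. Where it says the series, first, only, none or still open, it means among the compounds named here.

Compound 1 `COc1cc(C2=NN(C(C)=O)C(c3ccc([N+](=O)[O-])cc3)C2)cc(OC)c1OC` is the starting point; in a functional assay on L1210 cells (Mus musculus) for cytotoxicity, read by MTT assay, with a stated time of 72 h (on this read-out higher numbers stand for weaker inhibition and lower numbers for stronger inhibition), compound 1 gives 42000 nM. Compound 2 `COc1ccc(C2CC(c3cc(OC)c(OC)c(OC)c3)=NN2)cc1OC` gives 42000 nM in this assay, which is level with compound 1 within the scatter. Compound 3 `COc1cccc(C2CC(c3cc(OC)c(OC)c(OC)c3)=NN2C(C)=O)c1` has not yet been measured in this assay. It differs from compound 1 in one place: 3-methoxyphenyl in place of 4-nitrophenyl on a saturated ring carbon. Going by the values given here, no measured pair isolates this change, so the expectation is that no shift beyond the scatter follows from it. The expected step is therefore a 1.1-fold lower number from compound 1 to compound 3 (0.02 log units; within the scatter). On that basis compound 3 is expected to give about 40000 nM, with a range from 15000 nM to 110000 nM in this assay.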

Compound 3, half-maximal inhibitory concentration: 44000 nM
Compound 3: middle estimate off by 1.1-fold (0.04 log units), on the low side; measured number inside the range.
By their numbers in this assay, from the lowest: compounds 1, 2 and 3 (each within the scatter of the next).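

Within this assay the saturated ring carbon takes 3-methoxyphenyl in place of 4-nitrophenyl with a 1.0-fold higher number from compound 1 to compound 3 (0.02 log units; within the scatter) and so without a shift beyond the scatter. Going by these compounds alone, this is the first pair to isolate a change at this position, and it shows that these two groups are interchangeable here on this read-out. Nothing available explains this result.

The pair changes both the substituent and its place on the phenyl together, so it cannot separate the two. As far as these compounds go, whether an amine or a carboxylic acid on that phenyl would move the number remains open.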